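Cytotoxicity of a propargyloxymethyl analogue on HEL cells

The compounds below may be only part of what the source reports. "The series", "measured", "known", "first", "only" and "open" are said of these compounds alone.

Two compounds sharing one core have been examined in a functional assay on HEL cells (Homo sapiens); a higher number here means that more compound is tolerated, a lower number that less compound is tolerated. Compound 1 `O=C1c2ccccc2NS(=O)(=O)N1COCCO` gives 160 ug/mL in this assay. Compound 2 `CC(=O)OCCOCN1c2ccccc2C(=O)N(Cc2ccccc2)S1(=O)=O`, which carries a benzyl group and an acetoxyethoxymethyl chain on the shared core, gives 100 ug/mL in this assay. Within the data shown here, of the two numbers known so far, that of compound 2 is the smaller, but the gap to compound 1 lies within the usual scatter of repeated measurements, so the two compounds cannot be told apart on this evidence.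

Compound 3 `C#CCOCN1c2ccccc2C(=O)N(Cc2ccccc2)S1(=O)=O` is the next member. The difference from compound 2 is ethynyl in place of acetoxymethyl on a saturated chain carbon bound to an oxygen on a saturated carbon. Among the measured compounds shown here, no pair of measured compounds shows this or a comparable change, so nothing in the data indicates the direction of the step. Given that compound 1 and compound 2 sit close together despite different side chains, the step of no change at the digits printed from compound 2 to compound 3 (within the scatter) is expected to stay within the scatter. Compound 3 is therefore estimated at 100 ug/mL in this assay, with a range from 50 ug/mL to 200 ug/mL.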

Compound 3, half-maximal cytotoxic concentration: > 50 ug/mL
Compound 3 gave a limit, no number; the forecaster's own chance of this, stated with the estimate: 15%; the middle value lies beyond the limit too.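

In this assay, among these compounds, compound 3 gives > 50 ug/mL as a limit, not a number, and no step from compound 2 to compound 3 can be read from it. The compounds shown leave open whether ethynyl in place of acetoxymethyl on a saturated chain carbon bound to an oxygen on a saturated carbon shifts the tolerated concentration at all, and in which direction.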